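This account rests on a few compounds, and the source may have more. Where it says the series, first, only, none or still open, it means among the compounds named here.

Working notes on the series. The compounds share the core of compound 1 `Cn1cc(CN2CCC[C@H](OCc3cc(Cl)cc(Cl)c3)[C@@H]2c2ccccc2)cn1`. Going by the values given here, in an assay on isolated protein for activation of cGMP-dependent protein kinase 1 (Homo sapiens), read by ADP-Glo, with stated times of 120 min and 40 min (a lower number here means that less compound is needed, a higher number that more compound is needed for the effect), compound 1 gives 110000 nM, the highest of the three numbers measured so far; compound 2 `O=C(O)c1ccc(CN2CCC[C@H](O[C@H](CO)c3cc(Cl)cc(Cl)c3)[C@@H]2c2ccccc2)cc1` gives 11000 nM and compound 3 `O=C(O)c1ccc2c(CN3CCC[C@H](O[C@H](CO)c4cc(Cl)cc(Cl)c4)[C@@H]3c3ccccc3)c[nH]c2c1` gives 22000 nM. Compound 4 `Clc1cc(Cl)cc(CO[C@H]2CCCN(Cc3cccnc3)[C@H]2c2ccccc2)c1` differs from compound 1 in one place: pyridin-3-yl in place of 1-methyl-1H-pyrazol-4-yl on a saturated chain carbon bound to an amine nitrogen in a ring. Among the compounds with values here, the only measured step on a saturated chain carbon bound to an amine nitrogen in a ring is the one from compound 2 to compound 3, which gave a 2.0-fold higher number from compound 2 to compound 3 (0.30 log units; within the scatter). Within the data shown here, no measured compound carries a pyridin-3-yl, so the change from compound 1 to compound 4 is expected to move the number little, in no firm direction. Compound 4 is therefore estimated at 100000 nM, between 30000 nM and 300000 nM. The expected step is a 1.1-fold lower number from compound 1 to compound 4 (0.04 log units; within the scatter), within the scatter.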

Compound 4, half-maximal effective concentration: 112000 nM
Compound 4: middle estimate off by 1.1-fold (0.05 log units), on the low side; the range from low to high includes it.
By their numbers in this assay, from the lowest: compounds 2 and 3 (each within the scatter of the next); then compounds 1 and 4 (each within the scatter of the next).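

In this assay, pyridin-3-yl in place of 1-methyl-1H-pyrazol-4-yl on a saturated chain carbon bound to an amine nitrogen in a ring gives a 1.0-fold higher number from compound 1 to compound 4 (0.01 log units; within the scatter) and so leaves the number unmoved. At this position, a six-membered aromatic ring with 1 hetero atom and a five-membered one with 2 hetero atoms read alike in a pair without a carboxylic acid. No evidence bears on this result.

Compounds 2 and 3 each differ from compound 1 in more than one place, so the carboxylic acid and the hydroxymethyl group cannot be read apart. On these data alone, whether an amine on the pyridin-3-yl ring would move the number stays open.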